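Compound 4: imidazolyl swap in a flat series

This account rests on a few compounds, and the source may have more. Where it says the series, first, only, none or still open, it means among the compounds named here.

In a functional assay on U-251 cells (Homo sapiens) for inhibition, read by sulforhodamine B assay, with a stated time of 72 h (on this read-out lower numbers stand for an effect already at smaller amounts and higher numbers for an effect only at larger amounts of compound), compound 1 `CCC(=O)Oc1cccc2ccc(/C=C/c3ccccc3[N+](=O)[O-])nc12` gives 10100 nM, compound 2 `O=C(/C=C/c1ccc([N+](=O)[O-])o1)c1ccc(I)cc1` gives 12500 nM and compound 3 `CSc1ccc(C(=O)/C=C/c2ccc([N+](=O)[O-])o2)cc1` gives 14200 nM. These three numbers lie within the scatter of one another, so compound 3 has no separate standing among them.

Compound 4 `O=C(/C=C/c1ccc([N+](=O)[O-])o1)c1ccc(-n2ccnc2)cc1` keeps the core of compound 3 and carries 1H-imidazol-1-yl in place of methylsulfanyl on an aromatic carbon, para to a large group: 1H-imidazol-1-yl in place of methylsulfanyl on an aromatic carbon.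

Going by the values given here, the one measured step at this place is a 1.1-fold higher number from compound 2 to compound 3 (0.06 log units; within the scatter), with methylsulfanyl in place of iodo, and it stays within the scatter. Among the compounds with values here, that is thin evidence, since no measured compound carries an imidazolyl group. No step beyond the scatter is therefore expected in this assay, though the range is kept wide. The estimated change is a 1.1-fold lower number from compound 3 to compound 4 (0.04 log units; within the scatter). Compound 4 is expected at 13000 nM, with an estimated range of 6000 nM to 28000 nM.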

Compound 4, half-maximal effective concentration: 22600 nM
Compound 4: middle estimate off by 1.7-fold (0.24 log units), on the low side; low and high end bracket the measured number.
By their numbers in this assay, from the lowest: compounds 1, 2, 3 and 4 (each within the scatter of the next, the first and the last beyond it).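

In this assay, the position para to a large group now holds a ring, and the change still stays within the scatter: a 1.6-fold higher number from compound 3 to compound 4 (0.20 log units; within the scatter), and a 1.8-fold higher number from compound 2 to compound 4 (0.26 log units; within the scatter). Until now this position had shown only an exchange between two groups without a ring, whereas here 1H-imidazol-1-yl with 5 heavy atoms replaces methylsulfanyl with 2, and neither step separates the compounds. Nothing available bears on what lies behind these numbers.

As far as these compounds go, what an amine, a carboxylic acid or a longer chain at this position would do remains open, as does whether any group here can move the number beyond the scatter. Also open, from the compounds shown here alone, is whether this flat picture holds in other cell lines or on the core of compound 1, which differs from compounds 2, 3 and 4 in more than one place.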